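The source may hold more compounds than are shown below. What is called first, only, known or untested is meant among the compounds shown, and "the series" means these compounds.

Working notes on the series, step from compound 3 to compound 4. Compound 1 `COc1cc(-c2ncnn2-c2cccc(N)c2)cc(OC)c1OC` is tested in a functional assay on HL-60 cells (Homo sapiens) for antiproliferative activity, read by MTT assay, with a stated time of 72 h; a higher number here means a weaker inhibitor, a lower number a stronger inhibitor. In this assay compound 1 returns only the limit > 10000 nM, not a number. Compound 2 `COc1ccc(-n2ncnc2-c2cc(OC)c(OC)c(OC)c2)cc1` gives 6200 nM in this assay. Compound 3 `COc1cc(-c2ncnn2-c2ccc(Cl)cc2Cl)cc(OC)c1OC` likewise reaches only the limit > 10000 nM in this assay, not a number. Where compound 3 stands is therefore known only as a floor, set by the limit of > 10000 nM in this assay, at which 2 of the 3 values shown sit. Among the measured compounds shown here, the single readable move onto compound 3 is an at least 1.6-fold higher number from compound 2 to compound 3 (0.20 log units; that floor lies within the scatter); the move a step that the two limits leave unreadable from compound 1 to compound 3 gives no size; the move an at least 1.6-fold lower number from compound 1 to compound 2 (0.20 log units; that floor lies within the scatter) stays within scatter.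

Compound 4 `COc1cc(-c2ncnn2-c2ccc(F)cc2)cc(OC)c1OC` is not yet measured. The change is 4-fluorophenyl in place of 2,4-dichlorophenyl on an aromatic nitrogen. The 4-fluorophenyl resembles the 4-methoxyphenyl of compound 2 more than the 2,4-dichlorophenyl of compound 3, so the relevant comparison is the reverse of an at least 1.6-fold higher number from compound 2 to compound 3 (0.20 log units; that floor lies within the scatter), which was only a floor within scatter. A small downward step from compound 3 is expected, with a fair chance the limit is returned again. Compound 4 is estimated at 9000 nM, within 4000 nM to 20000 nM, the expected step being an at least 1.1-fold lower number from compound 3 to compound 4 (0.04 log units; that floor lies within the scatter).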

Compound 4, half-maximal inhibitory concentration: > 10000 nM
Compound 4: only a limit was reported; the forecaster's own chance of this, stated with the estimate: 50%; middle value at least 1.1-fold (0.04 log units) from the limit.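

Compound 4 returns only the limit > 10000 nM in this assay, not a number, so 4-fluorophenyl in place of 2,4-dichlorophenyl on this aromatic nitrogen gives no measurable value. Fluoro in place of methoxy on an aromatic carbon gives an at least 1.6-fold higher number from compound 2 to compound 4 (0.20 log units; that floor lies within the scatter), the only readable new step, and it does not separate the 4-fluorophenyl from the 4-methoxyphenyl. The other two new steps cannot be read, because both ends of each are limits: the limit of > 10000 nM in this assay, at which 3 of the 4 values shown sit.

From the compounds shown here alone, how far the 3-aminophenyl, 2,4-dichlorophenyl and 4-fluorophenyl compounds lie from one another remains unknown, and so does whether the 4-methoxyphenyl of compound 2 truly stands apart from them. Going by these compounds, it also remains open whether a 4-ethoxyphenyl, a 4-hydroxyphenyl or a phenyl bearing a carboxylic acid on this nitrogen would give a number in this assay.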